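Replacing the Furan-3-yl Group of Compound 3

The source may report more compounds than this note shows. Statements on the series, on what has been measured and on what is new or still open speak of the compounds shown alone.

In a functional assay on HCT-116 cells (Homo sapiens) for antiproliferative activity, read by sulforhodamine B assay (a higher number here means a weaker inhibitor, a lower number a stronger inhibitor), compound 1 (`CN1CCN(c2ccc(N/C=C3\C(=O)NC(=O)c4ccc(-c5ccoc5)cc43)cc2)CC1`) gives 1200 nM, compound 2 (`CN1CCN(c2ccc(N/C=C3\C(=O)NC(=O)c4ccc(-c5ccsc5)cc43)cc2)CC1`) gives 1400 nM and compound 3 (`O=C1NC(=O)c2ccc(-c3ccoc3)cc2/C1=C/Nc1ccc(CN2CCCCC2)cc1`) gives 1900 nM. These three numbers lie within the usual scatter of one another, so compound 3 stands level with the other two.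

Compound 4 (`O=C1NC(=O)c2ccc(-c3cccc(O)c3)cc2/C1=C/Nc1ccc(CN2CCCCC2)cc1`) has 3-hydroxyphenyl in place of furan-3-yl on an aromatic carbon.

For the measured compounds named here, two measured steps bear on this. The closer one, with thiophen-3-yl in place of furan-3-yl, is a 1.2-fold higher number from compound 1 to compound 2 (0.07 log units; within the scatter). The other, with (piperidin-1-yl)methyl in place of 4-methylpiperazin-1-yl, is a 1.6-fold higher number from compound 1 to compound 3 (0.20 log units; within the scatter) and concerns a different part of the molecule. Neither step exceeds the scatter. Going by the values given here, no measured compound carries a 3-hydroxyphenyl group, however, so this comparison is only a loose guide and the range must stay wide.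

The expected change is a 1.3-fold lower number from compound 3 to compound 4 (0.10 log units; within the scatter), which means no expected step beyond the scatter. The estimate for compound 4 is 1500 nM, with an expected range of 500 nM to 4500 nM.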

Compound 4, half-maximal inhibitory concentration: 1300 nM
Beside the measured number, compound 4's estimate is 1.2-fold (0.06 log units) above it, and the stated range covers the measured number.
By their numbers in this assay, from the lowest: compounds 1, 4, 2 and 3 (each within the scatter of the next).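

At this aromatic carbon of the shared core, a six-membered aromatic ring of carbon only can take the place of the five-membered furan-3-yl ring. In this assay this swap gives a 1.5-fold lower number from compound 3 to compound 4 (0.16 log units; within the scatter) and so the position tolerates 3-hydroxyphenyl, with seven heavy atoms against five and a hydrogen-bond donor that furan-3-yl lacks, without a step beyond the scatter. Nothing available explains why the number holds level across this change.

The compounds shown leave open whether the hydroxyl group matters at all, as a plain phenyl ring would be needed to separate it from the larger ring. They also leave open how an amine or a carboxylic acid in its place would fare, and whether 3-hydroxyphenyl behaves the same alongside 4-methylpiperazin-1-yl.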